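The source may hold more compounds than are shown below. What is called first, only, known or untested is meant among the compounds shown, and "the series" means these compounds.

Measured compounds:
- Compound 1 `Oc1nc2nonc2nc1Nc1ccc(Cl)cc1` — in an assay on mitochondria from L6 cells (Rattus norvegicus) for activation, with a stated time of 90 min (on this read-out lower numbers stand for an effect already at smaller amounts and higher numbers for an effect only at larger amounts of compound), compound 1 gives 11700 nM.
- Compound 2 `Oc1nc2nonc2nc1Nc1ccc(OC(F)(F)C(F)F)cc1` — in this assay compound 2 gives 7000 nM.

Among the measured compounds shown here, compound 2 carries the lower of the two numbers, but its only neighbour is close: the single measured step, a 1.7-fold lower number from compound 1 to compound 2 (0.22 log units; within the scatter), lies within the scatter, so the two compounds cannot be put in order on these data.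

Compound 3 `Oc1nc2nonc2nc1Nc1ccc(OC(F)(F)Cl)cc1` has not yet been measured in this assay. It differs from compound 2 in one place: chloro in place of difluoromethyl on a saturated chain carbon bound to two fluorine atoms and an oxygen on an aromatic ring. For the measured compounds named here, the one step so far exchanged chloro on an aromatic carbon for the whole 1,1,2,2-tetrafluoroethoxy group and was itself within the scatter; no measured pair touches the saturated chain carbon bound to two fluorine atoms and an oxygen on an aromatic ring. The data therefore give no ground to expect a step beyond the scatter from compound 2 to compound 3 in this assay, and the expected step is no change at the digits printed from compound 2 to compound 3 (within the scatter). On that basis compound 3 is estimated at 7000 nM, with a range from 3000 nM to 16000 nM.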

Compound 3, half-maximal effective concentration: 1900 nM
Estimate against measurement, compound 3: 3.7-fold (0.57 log units) above, outside the stated range (below it).
By their numbers in this assay, from the lowest: compound 3; then compounds 2 and 1 (each within the scatter of the next).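

In this assay the saturated chain carbon bound to two fluorine atoms and an oxygen on an aromatic ring proves to be a place where the read-out responds: chloro in place of difluoromethyl gives a 3.7-fold lower number from compound 2 to compound 3 (0.57 log units; beyond the scatter) and is the first single change shown that clears the scatter. The group on the aromatic carbon also now makes a readable difference, since chloro(difluoro)methoxy in place of chloro gives a 6.2-fold lower number from compound 1 to compound 3 (0.79 log units; beyond the scatter) while 1,1,2,2-tetrafluoroethoxy in that same place stayed within the scatter. Nothing available explains why the exchange at the chain carbon goes with a lower number.

As far as these compounds go, this rests on a single exchange at the chain carbon, so it remains open whether the shift belongs to chloro in particular or would also appear with fluorine, bromine or a methyl group on that carbon. From the compounds shown here alone, it is equally open whether the step would hold on a longer chain, or with an amine or a carboxylic acid elsewhere on the aromatic ring.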